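Swapping naphthalen-2-yl for 4-chlorophenyl on the shared core

This account rests on a few compounds, and the source may have more. Where it says the series, first, only, none or still open, it means among the compounds named here.

Compound 1 `CS(=O)(=O)Nc1ccc(-n2cc(-c3ccccc3)nn2)cc1Oc1ccccc1` gives 29900 nM
Compound 2 `CS(=O)(=O)Nc1ccc(-n2cc(COc3ccc4ccccc4c3)nn2)cc1Oc1ccccc1` gives 8300 nM

In a functional assay on A549 cells (Homo sapiens) for inhibition, read by MTT assay, with a stated time of 48 h (on this read-out lower numbers stand for stronger inhibition and higher numbers for weaker inhibition), compound 2 stands at 8300 nM, the lower of the two numbers. Compound 1 stands at 29900 nM, and the gap between the two lies beyond the scatter. Compound 3 `CS(=O)(=O)Nc1ccc(-n2cc(COc3ccc(Cl)cc3)nn2)cc1Oc1ccccc1` has not yet been measured. It keeps the core of compound 2 and carries a single change: 4-chlorophenyl in place of naphthalen-2-yl on an oxygen on a saturated carbon. Among the compounds with values here, no measured pair isolates a change of this kind, so the expectation rests on only two values. Compound 3 is expected to lie near compound 2 at 8300 nM, on the side towards compound 1 at 29900 nM. The expected step is a 1.6-fold higher number from compound 2 to compound 3 (0.19 log units; within the scatter), a modest rise in this assay that may not clear the scatter. For compound 3 the estimate is 13000 nM, with an expected range of 5500 nM to 32000 nM.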

Compound 3, half-maximal inhibitory concentration: 7100 nM
Compound 3: middle estimate off by 1.8-fold (0.26 log units), on the high side, within the range that was stated.
By their numbers in this assay, from the lowest: compounds 3 and 2 (each within the scatter of the next); then compound 1.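

Putting 4-chlorophenyl in place of naphthalen-2-yl on the oxygen gives a 1.2-fold lower number from compound 2 to compound 3 (0.07 log units; within the scatter) in this assay and so leaves the read-out within the scatter: at this position the smaller aryl group cannot be told apart from the larger one. Placing (4-chlorophenoxy)methyl in place of phenyl on the aromatic carbon gives a 4.2-fold lower number from compound 1 to compound 3 (0.62 log units; beyond the scatter) and lies beyond the scatter, which shows that this difference from compound 1 does not depend on naphthalen-2-yl. That step changes the link and the aryl group together, so it does not separate their shares.

The compounds shown leave open what the chlorine contributes, and how a plain phenoxy group, an amine or a carboxylic acid would read here. No independent measurement bears on why these numbers fall as they do.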